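This account rests on a few compounds, and the source may have more. Where it says the series, first, only, none or still open, it means among the compounds named here.

- compound 1 `Nc1nc2cc(-c3nn(CCCC(=O)NO)c4ncnc(N)c34)ccc2o1` gives 19500 nM
- compound 2 `Nc1nc2cc(-c3nn(CCCCCC(=O)NO)c4ncnc(N)c34)ccc2o1` gives 19000 nM

In a functional assay on MDA-MB-231 cells (Homo sapiens) for inhibition, read by MTT assay, with a stated time of 72 h (a lower number here means a stronger inhibitor, a higher number a weaker inhibitor), compound 2 gives 19000 nM and stands level with compound 1, since a 1.0-fold lower number from compound 1 to compound 2 (0.01 log units; within the scatter).

Compound 3 `Nc1nc2cc(-c3nn(CC(=O)NO)c4ncnc(N)c34)ccc2o1` carries hydroxycarbamoyl in place of 4-(hydroxycarbamoyl)butyl on a saturated chain carbon bound to an aromatic nitrogen.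

Within the data shown here, only one measured step bears on this change, and it also alters the chain: a 1.0-fold lower number from compound 1 to compound 2 (0.01 log units; within the scatter). No shift beyond the scatter is therefore expected in this assay, although this change removes more of the chain than that step did.

The estimated step is a 1.1-fold higher number from compound 2 to compound 3 (0.02 log units; within the scatter).

For compound 3 the expected value is 20000 nM, with an estimated range of 9000 nM to 45000 nM.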

Compound 3, half-maximal inhibitory concentration: 6310 nM
For compound 3 the middle estimate is 3.2-fold (0.50 log units) above the measured one; measured number outside the range, below it.
By their numbers in this assay, from the lowest: compound 3; then compounds 2 and 1 (each within the scatter of the next).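

In this assay the chain on the aromatic nitrogen does matter once it is cut to the (hydroxycarbamoyl)methyl of compound 3, which gives a 3.0-fold lower number from compound 2 to compound 3 (0.48 log units; beyond the scatter) and also a 3.1-fold lower number from compound 1 to compound 3 (0.49 log units; beyond the scatter). The two longer chains had stood level, so the earlier pair gave no sign of this drop. Nothing measured here accounts for the shift. Going by these compounds, it remains open whether a chain longer than 5-(hydroxycarbamoyl)pentyl would stay level with compounds 1 and 2, and whether a carboxylic acid in place of the hydroxycarbamoyl group would keep the lower number of compound 3.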